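A sulfonamide in place of the primary amide

The source may hold more compounds than are shown below. What is called first, only, known or untested is meant among the compounds shown, and "the series" means these compounds.

Compound 3 `Cn1nc2c(=O)n(CC3(O)CCN(Cc4ccc(-c5ccco5)cc4Cl)CC3)cnc2c1-c1ccc(C(N)=O)cc1` gives 80.8 nM in an assay on isolated protein for inhibition of ubiquitin carboxyl-terminal hydrolase 7 (Homo sapiens), with stated times of 30 min and 2 h (a higher number here means a weaker inhibitor, a lower number a stronger inhibitor), the highest number among the three measured compounds. Compound 1 `CC(C)NCc1ccc(-c2c3ncn(CC4(O)CCN(Cc5ccc(-c6ccco6)cc5Cl)CC4)c(=O)c3nn2C)cc1` gives 29.1 nM in this assay, and compound 2 `Cn1nc2c(=O)n(CC3(O)CCN(Cc4ccc(-c5ccco5)cc4Cl)CC3)cnc2c1-c1ccc(CNCCO)cc1` gives 8.2 nM. The measured steps run a 2.8-fold higher number from compound 1 to compound 3 (0.44 log units; beyond the scatter) and a 9.9-fold higher number from compound 2 to compound 3 (0.99 log units; beyond the scatter), so both compounds carrying a nitrogen-bearing substituent instead of the carbamoyl show lower numbers. Compound 4 `Cn1nc2c(=O)n(CC3(O)CCN(Cc4ccc(-c5ccco5)cc4Cl)CC3)cnc2c1-c1ccc(CNS(C)(=O)=O)cc1` differs from compound 3 by (methanesulfonamido)methyl in place of carbamoyl on an aromatic carbon. Its new group is a sulfonamide rather than an amine, so neither measured step matches it closely, and the expected step is modest and downward, a 2.3-fold lower number from compound 3 to compound 4 (0.36 log units; beyond the scatter), smaller than either measured step. Compound 4 is estimated at 35 nM in this assay, with a range from 12 nM to 110 nM.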

Compound 4, half-maximal inhibitory concentration: 65.3 nM
Compound 4: the middle estimate sits 1.9-fold (0.27 log units) below what was measured; the range from low to high includes it.
By their numbers in this assay, from the lowest: compound 2; then compound 1; then compounds 4 and 3 (each within the scatter of the next).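

In this assay, putting (methanesulfonamido)methyl in place of carbamoyl on this aromatic carbon leaves the number within the scatter (a 1.2-fold lower number from compound 3 to compound 4 (0.09 log units; within the scatter)). The methylene-linked nitrogen alone therefore does not bring the lower numbers of compound 1 and compound 2. What the nitrogen carries matters, since methylsulfonyl gives higher numbers than 2-hydroxyethyl (an 8.0-fold higher number from compound 2 to compound 4 (0.90 log units; beyond the scatter)) and isopropyl (a 2.2-fold higher number from compound 1 to compound 4 (0.35 log units; beyond the scatter)). Whether an acetyl on that nitrogen or a free primary amine would fall nearer compound 2 or compound 4 stays open, and nothing available gives a reason for these steps.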